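Chloro on the aryl ring of two related cores

The compounds below may be only part of what the source reports. "The series", "measured", "known", "first", "only" and "open" are said of these compounds alone.

Compound 1 `O=C1NCCN(c2ccccn2)N1` gives 8600 nM in a functional assay on cells for inhibition of Polyunsaturated fatty acid 5-lipoxygenase (Homo sapiens); on this read-out higher numbers stand for weaker inhibition and lower numbers for stronger inhibition. Compound 2 `O=C1NCCN(c2cccc(Cl)n2)N1` carries one extra group, (chloro in place of hydrogen on an aromatic carbon), and in this assay compound 2 gives 4800 nM. The step of a 1.8-fold lower number from compound 1 to compound 2 (0.25 log units; within the scatter) is small. Compound 3 `CC1CN(c2ccccc2)NC(=O)N1O` has a different core; the difference between the two cores is not broken down here. In this assay compound 3 gives 13000 nM.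

Compound 4 `CC1CN(c2cccc(Cl)c2)NC(=O)N1O` has not yet been measured. It differs from compound 3 by chloro in place of hydrogen on an aromatic carbon. This is the same kind of change as from compound 1 to compound 2, though the place is not identical: in compound 2 the chloro sits on a six-membered aromatic ring with 1 nitrogen, next to the ring nitrogen, meta to a group of 7 heavy atoms, while in compound 4 it sits on a six-membered aromatic ring of carbon only, meta to a group of 9 heavy atoms. Resting on the earlier step of a 1.8-fold lower number from compound 1 to compound 2 (0.25 log units; within the scatter), a similar small step a 1.6-fold lower number from compound 3 to compound 4 (0.21 log units; within the scatter) is expected. Compound 4 is therefore estimated at 8000 nM, likely between 3000 nM and 20000 nM.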

Compound 4, half-maximal inhibitory concentration: 3600 nM
For compound 4 the middle estimate is 2.2-fold (0.35 log units) above the measured one, and the stated range covers the measured number.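

Chloro in place of hydrogen on an aromatic carbon gives a 3.6-fold lower number from compound 3 to compound 4 (0.56 log units; beyond the scatter) in this assay and so counts as a modest but real gain in inhibition on this core. Set beside the earlier step, the size of the change does not differ measurably between the two cores, so the data fit a change that carries over: the same change on two cores in this assay, a 1.8-fold lower number (0.25 log units; within the scatter) from compound 1 to compound 2 and a 3.6-fold lower number (0.56 log units; beyond the scatter) from compound 3 to compound 4, 2.0-fold (0.30 log units) apart, within the scatter of two such steps

Among these compounds, this rests on only two pairs, and the step on the core of compound 1 lies within the scatter by itself, so it does not prove that chloro strengthens inhibition on that core or on any further core. Nor does it explain the steps, and the chloro also sits on a different kind of ring in each pair.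

The compounds shown leave open whether another group in the same place, such as methyl, methoxy or an amine, would match chloro. They also leave open whether chloro elsewhere on the ring would give a step of similar size.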